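Chloro-to-hydrogen step on the aryl of compound 2

The compounds below may be only part of what the source reports. "The series", "measured", "known", "first", "only" and "open" are said of these compounds alone.

Measured so far in a functional assay on RPMI-8226 cells (Homo sapiens) for antiproliferative activity; on this read-out higher numbers stand for weaker inhibition of growth and lower numbers for stronger inhibition of growth:
compound 1 `COc1ccc(-n2cc(-c3ccc(Cl)cc3)[nH]c2=S)cc1Cl` gives 50100 nM
compound 2 `COc1cc(-n2cc(-c3ccc(Cl)cc3)[nH]c2=O)cc(OC)c1OC` gives 12600 nM
compound 3 `COc1ccc(-n2cc(-c3ccc(OC)c(OC)c3)[nH]c2=S)cc1Cl` gives only a limit, > 100000 nM

Compound 2 holds the lowest of the two numbers in this assay; the nearest number, that of compound 1, lies above it by a gap beyond the usual scatter. The entry for compound 3 is a limit of this assay and not a number (the limit of > 100000 nM in this assay, at which 1 of the 3 values shown sits). Among the compounds with values here, compound 1 and compound 3 each differ from compound 2 in more than one place, so no single step between measured compounds is available, and what compound 1 and compound 3 show is only their own values.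

Compound 4 `COc1cc(-n2cc(-c3ccccc3)[nH]c2=O)cc(OC)c1OC` differs from compound 2 in one place: hydrogen in place of chloro on an aromatic carbon. Within the data shown here, no measured pair carries this exchange, so its effect has to be estimated from compound 2 alone. The step expected from compound 2 to compound 4 in this assay, a 1.7-fold higher number from compound 2 to compound 4 (0.24 log units; within the scatter), is small, at or just beyond the scatter, toward a higher number, with none beyond the scatter also plausible. Compound 4 is estimated at 22000 nM, with a range from 8000 nM to 65000 nM.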

Compound 4, concentration for 50% growth inhibition: > 100000 nM
Compound 4 gave a limit, no number; the forecaster's own chance of this, stated with the estimate: 10%; middle value at least 4.5-fold (0.65 log units) from the limit.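

In this assay, within the data shown here, the change from 4-chlorophenyl to phenyl gives the first single-place comparison, and it reads as an at least 7.9-fold higher number from compound 2 to compound 4 (0.89 log units; beyond the scatter). The chloro on this aromatic carbon, para to a large group, therefore matters for the growth inhibition measured for compound 2, as taking it away on this core leaves no measurable number in the assay, a far larger loss than a swap of one atom for hydrogen might suggest. The step gives only a lower bound on the size of the change, as the entry for compound 4 is a limit of the assay and not a number, and this limit now holds for more than one compound of the series: the limit of > 100000 nM in this assay, at which 2 of the 4 values shown sit.

The compounds shown leave open whether chloro itself is needed here or whether another group on the same carbon, such as fluoro, bromo, methyl or methoxy, or an amine, would serve as well or better. They also leave open whether the same exchange would carry the same weight on the core of compound 1, which bears the same 4-chlorophenyl.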